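Two-compound series: methylamino for methyl on the acyl chain

The source may report more compounds than this note shows. Statements on the series, on what has been measured and on what is new or still open speak of the compounds shown alone.

Of the compounds shown here, two so far carry numbers in a functional assay on PC-3 cells (Homo sapiens) for cytotoxicity, read by MTT assay, with a stated time of 48 h; a lower number here means a stronger inhibitor, a higher number a weaker inhibitor. Compound 1 `CC1=NN(S(=O)(=O)c2ccc(C)cc2)C(c2cc(Br)cc(Br)c2O)C1` gives 51200 nM in this assay. Compound 2 `CCC(=O)N1N=C(c2cc3ccccc3oc2=O)CC1c1ccccc1` gives 4370 nM in this assay, the lower of the two numbers; the gap between compound 1 and compound 2 lies beyond the usual scatter, so compound 2 stands as the stronger inhibitor of the pair. The two compounds share no common structure beyond what their drawings show, so the gap between them is not assigned to any single change.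

Compound 3 `CNCC(=O)N1N=C(c2cc3ccccc3oc2=O)CC1c1ccccc1` is the next compound to go into this assay. It differs from compound 2 in one place: methylamino in place of methyl on a saturated chain carbon bound to a carbonyl carbon. Within the data shown here, no measured pair shows this change, so there is no step to lean on; the expectation is a step within the scatter, leaning slightly toward a lower number. Compound 3 is therefore expected to show a change of a 1.2-fold lower number from compound 2 to compound 3 (0.10 log units; within the scatter) against compound 2. Compound 3 is estimated at 3500 nM in this assay, with a range from 1200 nM to 12000 nM.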

Compound 3, half-maximal inhibitory concentration: 2300 nM
Beside the measured number, compound 3's estimate is 1.5-fold (0.18 log units) above it, and the stated range covers the measured number.
By their numbers in this assay, from the lowest: compounds 3 and 2 (each within the scatter of the next); then compound 1.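

In this assay, the acyl chain now has its first readable step: a 1.9-fold lower number from compound 2 to compound 3 (0.28 log units; within the scatter), for methylamino in place of methyl on a saturated chain carbon bound to a carbonyl carbon. The propanoyl of compound 2 can therefore become the ((methylamino)methyl)carbonyl of compound 3, with its added nitrogen and hydrogen-bond donor and acceptor counts, without the two compounds separating in this read-out. No supporting data bear on why the pair reads this way, so this single step gives no account of the role of the added group.

Going by these compounds, whether a dimethylamino group, a hydroxyl group or a carboxylic acid at this place, or a longer chain ending in an amine, would move the number beyond the scatter remains open. Among these compounds, compound 1 differs from compound 2 and compound 3 in more than one place, so it gives no step on this question, and the series still offers only one comparison at this position.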